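This account rests on a few compounds, and the source may have more. Where it says the series, first, only, none or still open, it means among the compounds named here.

Compound 1 `Cc1ccc(S(=O)(=O)N[C@@H](CC(=O)NC(C)(C)C)C(=O)NCCNC(=O)c2cc(Cl)ccn2)cc1` was tested in an ADME assay on Karpas-1106P cells (Homo sapiens) for cytotoxicity; a higher number here means that more compound is needed for the effect, a lower number that less compound is needed. In this assay compound 1 gives > 11100 nM, which is a limit of the assay rather than a measured number. Compound 2 `Cc1ccc(S(=O)(=O)N[C@@H](CC(=O)NC(C)(C)C)C(=O)NCCNC(=O)c2cccc(C(C)C)c2)cc1` gives > 11100 nM in this assay, again only a limit. Compound 3 `Cc1ccc(S(=O)(=O)N[C@@H](CC(=O)NC(C)(C)C)C(=O)NCCNC(=O)c2ccccc2Cl)cc1` gives > 11100 nM in this assay, also a limit. Compound 1 therefore stands at the same limit as the two other compounds, and every step among the three, a step that the two limits leave unreadable from compound 1 to compound 2, a step that the two limits leave unreadable from compound 1 to compound 3 and a step that the two limits leave unreadable from compound 2 to compound 3, has no readable size. Compound 4 `Cc1ccc(S(=O)(=O)N[C@@H](CC(=O)NC(C)(C)C)C(=O)NCCNC(=O)c2ccc(Cl)cc2)cc1` has not yet been measured in this assay. It differs from compound 1 by 4-chlorophenyl in place of 4-chloropyridin-2-yl on a carbonyl carbon. The measured steps that bear on this change all exchange the group on that carbonyl carbon, yet none of them shows a size, because of the limit of > 11100 nM in this assay, at which 3 of the 3 values shown sit. No step beyond the usual scatter can be read from them in either direction, and the new group is of the same kind as those already tried. Compound 4 is expected in this assay to give 15000 nM, most likely reported again only as a limit, within a range from 8000 nM to 40000 nM. The step expected is a step that the limit leaves unreadable from compound 1 to compound 4.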

Compound 4, half-maximal effective concentration: > 11100 nM
Compound 4 ended at the assay's limit; the forecaster's own chance of this, stated with the estimate: 85%; the middle value does not contradict the limit.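

In this assay compound 4 gives > 11100 nM, which is a limit of the assay and not a measured number. Its steps to compound 1, compound 2 and compound 3 cannot be read: the limit of > 11100 nM in this assay, at which 4 of the 4 values shown sit. The compounds shown leave open what concentration any of them needs for the effect, and whether exchanging the group on the carbonyl carbon changes it.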